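Hydroxyphenyl in Place of Chlorophenyl on a Shared Core

The source may hold more compounds than are shown below. What is called first, only, known or untested is meant among the compounds shown, and "the series" means these compounds.

The measured compounds, in a functional assay on the whole organism (strain albino) for inhibition, with Rattus norvegicus as the target, read by paw edema, with stated times of 1 h and 3 h, at a dose of 100 mg/kg by the oral route; on this read-out lower numbers stand for a weaker effect and higher numbers for a stronger effect at the one dose given:
compound 1 `N#Cc1c(-c2ccc(O)cc2)nc(SCC(=O)Nn2c(COc3ccc(Cl)cc3Cl)nc3ccccc3c2=O)[nH]c1=O` gives 68.4%
compound 2 `O=C(CSc1nc(-c2ccccc2)c(C(=O)O)c(=O)[nH]1)Nn1c(COc2ccc(Cl)cc2Cl)nc2ccccc2c1=O` gives 64.9%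
compound 3 `O=C(CSc1nc(-c2ccc(Cl)cc2)c(C(=O)O)c(=O)[nH]1)Nn1c(COc2ccc(Cl)cc2Cl)nc2ccccc2c1=O` gives 61.4%

The three numbers lie close together, and the gaps between compound 3 and the other two are within the scatter, so compound 3 cannot be set apart from compound 2 or compound 1 on these data. For the measured compounds named here, the one step between neighbours that differ in a single place, a number 3.5 percentage points lower from compound 2 to compound 3 (within the scatter), likewise stays within the scatter.

Compound 4 `O=C(CSc1nc(-c2ccc(O)cc2)c(C(=O)O)c(=O)[nH]1)Nn1c(COc2ccc(Cl)cc2Cl)nc2ccccc2c1=O` is the next member. It differs from compound 3 by hydroxy in place of chloro on an aromatic carbon. Going by the values given here, no measured step bears directly on this exchange. The closest guide is compound 1, which also carries a hydroxyphenyl group on the same position of the core yet differs elsewhere, and its reading sits near those of compound 2 and compound 3. With that, and with the step from compound 2 to compound 3 being within the scatter, the expected step of a number 2.6 percentage points higher from compound 3 to compound 4 (within the scatter) in this assay is small and of no fixed direction. Compound 4 is therefore estimated at 64%, with a range from 54% to 74%.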

Compound 4, a percentage reported as inhibition, in the whole organism at one dose (the size of the read-out at that dose, not a potency): 38.6%
Beside the measured number, compound 4's estimate is 25.4 percentage points above it; the measured number lies below the stated range.
By their numbers in this assay, from the lowest: compound 4; then compounds 3, 2 and 1 (each within the scatter of the next).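

In this assay, the exchange of 4-chlorophenyl for 4-hydroxyphenyl on the carboxy-bearing core gives a number 22.8 percentage points lower from compound 3 to compound 4 (beyond the scatter), and hydroxy in place of hydrogen on the same aromatic carbon gives a number 26.3 percentage points lower from compound 2 to compound 4 (beyond the scatter), whereas chloro in place of hydrogen gave only a number 3.5 percentage points lower from compound 2 to compound 3 (within the scatter); of the three groups tried at this place, hydroxy alone sets its compound apart. With the 4-hydroxyphenyl group kept in place, carboxy in place of cyano gives a number 29.8 percentage points lower from compound 1 to compound 4 (beyond the scatter), so among these compounds the hydroxyphenyl group does not go with a low reading by itself, but only together with the carboxy group on the shared core. Nothing available explains this drop or the dependence on the neighbouring group.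

Going by these compounds, it remains open whether a methoxy group or an amine on that aromatic carbon would read like hydroxy or like chloro. The compounds shown also leave open how the phenyl and 4-chlorophenyl groups behave with cyano in place of carboxy, which would show whether the two places truly depend on each other.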